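The source may report more compounds than this note shows. Statements on the series, on what has been measured and on what is new or still open speak of the compounds shown alone.

Working notes on the series in a functional assay on HT529 cells (Homo sapiens) for cytotoxicity; a lower number here means a stronger inhibitor, a higher number a weaker inhibitor. Compound 3 `CCCCCCCCCCCCCC[C@@H]1N[C@H](CO)[C@H]1O` gives 0.79 ug/mL. Compound 1 `CCCCCCCCCCCCCC[C@H]1N[C@H](CO)[C@H]1O` gives 1.23 ug/mL; the step of a 1.6-fold lower number from compound 1 to compound 3 (0.19 log units; within the scatter) rests on (the fact that compounds 1 and 3 differ only in the configuration as drawn). For compound 2 `CC(C)CC[C@H](O)CCCCCCCCC[C@@H]1N[C@@H](CO)[C@@H]1O` the value > 2 ug/mL is a limit of the measurement, not a number (the limit of > 2 ug/mL in this assay, at which 1 of the 3 values shown sits). Compound 3 therefore holds the lowest of the two numbers given, with compound 1 within the scatter of it. Compound 4 `CCCCCCCCCCCCCC[C@H]1N[C@@H](CO)[C@H]1O` is not yet measured; against compound 3 the change is the two compounds have the same atoms and bonds and differ only in configuration as drawn: 2 of 3 stereo elements differ; a stereocentre at a saturated ring carbon is drawn S in compound 3 and R in compound 4; a stereocentre at a saturated ring carbon is drawn R in compound 3 and S in compound 4. Among the measured compounds shown here, the only measured step that bears on it, a 1.6-fold lower number from compound 1 to compound 3 (0.19 log units; within the scatter), was a single change of configuration that stayed within the scatter, so compound 4 is expected to shift only a little, a 1.3-fold higher number from compound 3 to compound 4 (0.10 log units; within the scatter). Compound 4 is thus estimated at 1 ug/mL, with a range from 0.4 ug/mL to 2.5 ug/mL.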

Compound 4, half-maximal inhibitory concentration: 1.65 ug/mL
The estimate for compound 4 lay 1.7-fold (0.22 log units) below the measured number; the measured number falls inside the stated range.
By their numbers in this assay, from the lowest: compounds 3, 1 and 4 (each within the scatter of the next, the first and the last beyond it). At a limit, above all of these: compound 2.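

Among the compounds shown here, compound 4 gives the first step that leaves the scatter, in this assay: a 2.1-fold higher number from compound 3 to compound 4 (0.32 log units; beyond the scatter). For the compounds shown here, that step takes two changes of configuration at saturated ring carbons together, while the single change in a 1.3-fold higher number from compound 1 to compound 4 (0.13 log units; within the scatter) stays inside the scatter. Across these three stereoisomers, configuration therefore moves the number only modestly.

From the compounds shown here alone, whether either changed stereocentre alone accounts for the larger step remains open, as does whether a shorter chain or a terminal carboxylic acid on the chain would shift the number further than configuration does.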